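Swapping the amide substituent in a cholesterol transporter binder

The source may hold more compounds than are shown below. What is called first, only, known or untested is meant among the compounds shown, and "the series" means these compounds.

Compound 1 `CC(C)(C)c1ccc(C(=O)N2CCC3(CC2)C(=O)N(CC(=O)N2CCC(CCO)CC2)CN3c2ccccc2)cc1` — 2600 nM
Compound 2 `CC(C)(C)OC(=O)NCCNC(=O)CN1CN(c2ccccc2)C2(CCN(C(=O)c3ccc(C(C)(C)C)cc3)CC2)C1=O` — 10900 nM
Compound 3 `CC(C)(C)c1ccc(C(=O)N2CCC3(CC2)C(=O)N(CC(=O)N2CCN(S(C)(=O)=O)CC2)CN3c2ccccc2)cc1` — 19000 nM

Of the compounds shown here, three sharing one core have been tested in an assay on HEK293 cells for displacement of a labelled ligand from NPC1-like intracellular cholesterol transporter 1 (Homo sapiens); on this read-out lower numbers stand for stronger inhibition and higher numbers for weaker inhibition. Compound 3 gives 19000 nM, the highest number of the three; its nearest neighbour is compound 2, and the gap there, a 1.7-fold higher number from compound 2 to compound 3 (0.24 log units; within the scatter), is within the usual scatter. The distance to compound 1 is larger: a 7.3-fold higher number from compound 1 to compound 3 (0.86 log units; beyond the scatter), and a 4.2-fold higher number from compound 1 to compound 2 (0.62 log units; beyond the scatter).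

Compound 4 `CC(C)(C)c1ccc(C(=O)N2CCC3(CC2)C(=O)N(CC(=O)N2CCCCC2CCO)CN3c2ccccc2)cc1` has not yet been measured in this assay. It differs from compound 3 in one place: 2-(2-hydroxyethyl)piperidin-1-yl in place of 4-(methylsulfonyl)piperazin-1-yl on a carbonyl carbon. The group that enters is a close relative of the group carried by compound 1, which is the strongest binder among the measured compounds. The step from compound 1 to compound 3, replacing that group with the sulfonyl piperazine, raised the number clearly. Reversing the direction of that change, with the hydroxyethyl chain now attached elsewhere on the piperidine ring, is expected to bring the number back down by a substantial part of that distance, though the shift in where the chain sits leaves the exact outcome uncertain. The expected step is a 4.2-fold lower number from compound 3 to compound 4 (0.63 log units; beyond the scatter). Compound 4 is therefore estimated at 4500 nM, with a range from 1500 nM to 13000 nM.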

Compound 4, half-maximal inhibitory concentration: 6100 nM
For compound 4 the middle estimate is 1.4-fold (0.13 log units) below the measured one, and the stated range covers the measured number.
By their numbers in this assay, from the lowest: compound 1; then compounds 4, 2 and 3 (each within the scatter of the next, the first and the last beyond it).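

The two hydroxyethyl piperidines differ only in where the chain sits on the ring, and in this assay that difference alone gives a 2.3-fold higher number from compound 1 to compound 4 (0.37 log units; beyond the scatter), so at this position on the carbonyl carbon the location of the chain counts, not just its presence. The moved group still does better than the sulfonyl piperazine, with a 3.1-fold lower number from compound 3 to compound 4 (0.49 log units; beyond the scatter), so both hydroxyethyl piperidines give clearly lower numbers than 4-(methylsulfonyl)piperazin-1-yl. Against the open-chain (2-((tert-butoxycarbonyl)amino)ethyl)amino group the picture differs: a 1.8-fold lower number from compound 2 to compound 4 (0.25 log units; within the scatter) leaves these two groups unresolved, so the 2-(2-hydroxyethyl)piperidin-1-yl group cannot be ranked against it.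

Nothing available here explains why the location of the chain should matter. The compounds shown also leave open how much of the difference belongs to the hydroxyl group itself, a question that a plain piperidin-1-yl with no chain, a methoxyethyl chain in place of the hydroxyethyl chain, or a longer chain ending in a hydroxyl group could help to settle.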